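Swapping Benzoyl for Phenylsulfonyl on a Shared Core

A few compounds are considered here, and "the series" means these few. Any claim that something is new, unique, unknown or untested is made for them only; others in the source may bear on it.

Of the compounds shown here, three that share a common core have been tested in an assay on isolated protein for inhibition of 3',5'-cyclic-AMP phosphodiesterase 4A (Cavia porcellus), read by cAMP accumulation, tested at 50 uM; a lower number here means a weaker effect, a higher number a stronger effect of the compound at the concentration tested. Compound 1 `CC(=O)c1cc(C(=O)c2ccccc2)c(=O)[nH]c1C` gives 4.35%. Compound 2 `O=C1CCCc2[nH]c(=O)c(C(=O)c3ccccc3)cc21` gives 4.3%. Compound 3 `O=C1CC(c2ccccc2)Cc2[nH]c(=O)c(C(=O)c3ccccc3)cc21` gives 1.7%. Compound 3 holds the lowest of the three numbers, yet the step of a number 2.6 percentage points lower from compound 2 to compound 3 (within the scatter) is within the scatter, and the values of compound 1 and compound 3 sit close together as well, so none of the three can be told apart by this assay; all three produce only slight inhibition.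

Compound 4 `O=C1CC(c2ccccc2)Cc2[nH]c(=O)c(S(=O)(=O)c3ccccc3)cc21` has not yet been measured. It differs from compound 3 in one place: phenylsulfonyl in place of benzoyl on an aromatic carbon

Among the compounds with values here, the only measured step, a number 2.6 percentage points lower from compound 2 to compound 3 (within the scatter), concerns a phenyl on a saturated ring carbon, a different group in a different place, so it gives no direct guide to a benzoyl-to-phenylsulfonyl exchange. Within the data shown here, what the measured set does show is that every value stays low and no step reaches beyond the scatter. On that basis the expectation for compound 4 is a step of a number 1.3 percentage points higher from compound 3 to compound 4 (within the scatter), meaning no change beyond the scatter. Compound 4 is therefore estimated to give 3%, with a range from -8% to 14%.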

Compound 4, a percentage reported as inhibition, at one concentration (the size of the read-out at that concentration, not a potency): 5.7%
For compound 4 the middle estimate is 2.7 percentage points below the measured one; measured number inside the range.
By their numbers in this assay, from the lowest: compounds 3, 2, 1 and 4 (each within the scatter of the next).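

Exchanging benzoyl for phenylsulfonyl on this aromatic carbon gives a number 4 percentage points higher from compound 3 to compound 4 (within the scatter), so this assay does not separate the two groups, even though the phenylsulfonyl group brings a sulfur atom and an extra hydrogen-bond acceptor. Within the data shown here, this is the first change at this position, as the earlier step altered only a saturated ring carbon, and it shows that this exchange yields no gain in inhibition beyond the scatter; with compound 3 already giving so little inhibition, the assay also has little room to reveal a loss. No separate measurement is available to explain why the two groups read alike.

On these data alone, it remains open whether a quite different group on this aromatic carbon, such as an amine, a carboxylic acid or a longer alkyl chain, would raise inhibition beyond the scatter. It is also unknown whether the same benzoyl-to-phenylsulfonyl exchange would read alike on the core of compound 2, which lacks the phenyl on the saturated ring.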